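The compounds below may be only part of what the source reports. "The series", "measured", "known", "first", "only" and "open" are said of these compounds alone.

The four compounds share one core in two forms: compound 2 `Cn1cc(-c2ccccc2Oc2ccccc2)c2cc(C(=O)NCc3ccc(C(=O)NO)cc3)[nH]c2c1=O` and compound 1 `Cn1cc(-c2ccccc2Oc2ccccc2)c2cc(C(=O)NCCCCCCC(=O)NO)[nH]c2c1=O` carry the simpler form, while compound 3 `Cn1cc(-c2cc(C(C)(C)O)ccc2Oc2ccc(F)cc2F)c2cc(C(=O)NCc3ccc(C(=O)NO)cc3)[nH]c2c1=O` and the unmeasured compound 4 `Cn1cc(-c2cc(C(C)(C)O)ccc2Oc2ccc(F)cc2F)c2cc(C(=O)NCCCCCCC(=O)NO)[nH]c2c1=O` carry the other. The difference between the two cores is not broken down here. In a functional assay on MV4-11 cells (Homo sapiens) for antiproliferative activity, read by CCK-8 assay, with a stated time of 72 h (a lower number here means a stronger inhibitor, a higher number a weaker inhibitor), compound 2 gives 570 nM and compound 1 gives 180 nM, and the change 5-(hydroxycarbamoyl)pentyl in place of 4-(hydroxycarbamoyl)phenyl on a saturated chain carbon bound to an amide-type nitrogen made the step of a 3.2-fold lower number from compound 2 to compound 1 (0.50 log units; beyond the scatter). Compound 3 gives 190 nM in this assay, close to compound 1. Compound 4 is reached from compound 3 by the same change, (5-(hydroxycarbamoyl)pentyl in place of 4-(hydroxycarbamoyl)phenyl on a saturated chain carbon bound to an amide-type nitrogen), at the same place. The earlier step of a 3.2-fold lower number from compound 2 to compound 1 (0.50 log units; beyond the scatter) lay beyond the scatter, so compound 4 is expected to take a step of about the same size, a 3.2-fold lower number from compound 3 to compound 4 (0.50 log units; beyond the scatter). The estimate for compound 4 in this assay is 60 nM, expected to fall between 25 nM and 150 nM.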

Compound 4, half-maximal inhibitory concentration: 250 nM
Beside the measured number, compound 4's estimate is 4.2-fold (0.62 log units) below it, and the stated range ends below it.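

In this assay, among these compounds, the change from 4-(hydroxycarbamoyl)phenyl to 5-(hydroxycarbamoyl)pentyl gave a 1.3-fold higher number from compound 3 to compound 4 (0.12 log units; within the scatter) and so produced no step that stands out from the scatter on this core. The gain seen on the simpler core did not carry over to the other: the same change on two cores in this assay, a 3.2-fold lower number (0.50 log units; beyond the scatter) from compound 2 to compound 1 and a 1.3-fold higher number (0.12 log units; within the scatter) from compound 3 to compound 4, 4.2-fold (0.62 log units) apart, beyond the scatter of two such steps. This shows that the step cannot be transferred between these two cores, but it does not show which part of the difference between them is responsible or how the change would behave on any further core.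

The compounds shown leave open whether a longer chain than 5-(hydroxycarbamoyl)pentyl would behave alike on both cores. They also leave open what a carboxylic acid in place of the hydroxycarbamoyl group would do.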